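The source may report more compounds than this note shows. Statements on the series, on what has been measured and on what is new or still open speak of the compounds shown alone.

In an in vitro functional assay on cells for agonist activity at Bombesin receptor subtype-3 (Mus musculus), read by luminescence and calcium flux (a lower number here means that less compound is needed, a higher number that more compound is needed for the effect), compound 1 `O=C(O)c1ccccc1-c1ccc(CCc2ncc(CC3CCCCC3)[nH]2)cc1` gives 7.3 nM. Compound 2 `O=C(O)c1ccccc1-c1ccc(CCc2ncc(CC3CCCC3)[nH]2)cc1` gives 7.9 nM. Compound 3 `COc1cccc(Cc2cnc(CCc3ccc(-c4ccccc4C(=O)O)cc3)[nH]2)c1` gives 79 nM.

Compound 3 stands highest of the three numbers: the steps of an 11-fold higher number from compound 1 to compound 3 (1.03 log units; beyond the scatter) and a 10-fold higher number from compound 2 to compound 3 (1.00 log units; beyond the scatter) are both beyond the scatter, whereas a 1.1-fold higher number from compound 1 to compound 2 (0.03 log units; within the scatter) is within it. Compound 4 `Cc1cccc(Cc2cnc(CCc3ccc(-c4ccccc4C(=O)O)cc3)[nH]2)c1` differs from compound 3 by methyl in place of methoxy on an aromatic carbon. Within the data shown here, none of the measured steps alters a substituent on that aromatic ring; the two steps leading to compound 3 exchange the whole ring for a saturated one and so do not bear directly on this change. With nothing in the set pointing either way, the step of a 1.2-fold lower number from compound 3 to compound 4 (0.08 log units; within the scatter) in this assay is expected to stay within the scatter. Compound 4 is estimated at 65 nM, with a range of 20 nM to 200 nM.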

Compound 4, half-maximal effective concentration: 75 nM
The estimate for compound 4 lay 1.2-fold (0.06 log units) below the measured number; low and high end bracket the measured number.
By their numbers in this assay, from the lowest: compounds 1 and 2 (each within the scatter of the next); then compounds 4 and 3 (each within the scatter of the next).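

At this position on the 3-substituted benzyl group, a 1.1-fold lower number from compound 3 to compound 4 (0.02 log units; within the scatter) in this assay, so exchanging methoxy for methyl, with the loss of the oxygen and its hydrogen-bond acceptor, leaves the number within the scatter. The gap to the saturated groups remains with methyl on the ring, as a 9.5-fold higher number from compound 2 to compound 4 (0.98 log units; beyond the scatter) and a 10-fold higher number from compound 1 to compound 4 (1.01 log units; beyond the scatter), so it does not depend on the methoxy group. No measured data offer an explanation for these steps. Left open is whether an unsubstituted phenyl, or a hydroxyl, chlorine or amine on this ring, stays with compound 3 and compound 4 or closes the gap to compound 1.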